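The source may report more compounds than this note shows. Statements on the series, on what has been measured and on what is new or still open speak of the compounds shown alone.

Compound 1 `Cc1nc2cc(Cl)c(Cl)cc2n1C1CCCC1`: 40000 nM
Compound 2 `CCc1nc2cc(Cl)c(Cl)cc2n1C1CCCC1`: 52000 nM
Compound 3 `FC(F)(F)c1nc2cc(Cl)c(Cl)cc2n1C1CCCC1`: 21000 nM

These three compounds share one core and differ only in a single small group, and all were tested in a functional assay on MCF7 cells (Homo sapiens) for cytotoxicity, read by MTT assay, with a stated time of 48 h; on this read-out higher numbers stand for weaker inhibition of growth and lower numbers for stronger inhibition of growth. Compound 3, at 21000 nM, is placed by two steps. The first, a 1.9-fold lower number from compound 1 to compound 3 (0.28 log units; within the scatter), does not separate the pair. The second, a 2.5-fold lower number from compound 2 to compound 3 (0.39 log units; beyond the scatter), is the one clear gap among the three.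

The next compound is compound 4 `CC(C)c1nc2cc(Cl)c(Cl)cc2n1C1CCCC1`. The change is isopropyl in place of trifluoromethyl on an aromatic carbon, between two ring nitrogen atoms.

Among the compounds with values here, no isopropyl compound has been measured yet, so the closest guide is the pair carrying plain carbon chains. Extending the chain changed little, with a 1.3-fold higher number from compound 1 to compound 2 (0.11 log units; within the scatter). Isopropyl is one more carbon chain group, so compound 4 should land near compound 1 and compound 2 rather than near compound 3. In this assay that points to a higher number, about as large as the one clear gap, though in the opposite direction. The expected step is a 2.4-fold higher number from compound 3 to compound 4 (0.38 log units; beyond the scatter). Compound 4 is estimated at 50000 nM, with an expected range from 25000 nM to 100000 nM.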

Compound 4, concentration for 50% growth inhibition: 43000 nM
The estimate for compound 4 lay 1.2-fold (0.07 log units) above the measured number; the range from low to high includes it.
By their numbers in this assay, from the lowest: compounds 3, 1, 4 and 2 (each within the scatter of the next, the first and the last beyond it).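

In this assay, within the data shown here, isopropyl, the first branched carbon group at this position, between two ring nitrogen atoms, does not stand apart from the smaller carbon groups: a 1.1-fold higher number from compound 1 to compound 4 (0.03 log units; within the scatter) and a 1.2-fold lower number from compound 2 to compound 4 (0.08 log units; within the scatter) both lie within the scatter, so methyl, ethyl and isopropyl cannot be told apart here. The exchange of trifluoromethyl for isopropyl gives a second modest gap beyond the scatter, a 2.0-fold higher number from compound 3 to compound 4 (0.31 log units; beyond the scatter), so compound 3 now stands apart from both compound 2 and compound 4, while compound 1 goes against any clean split between trifluoromethyl and the carbon groups, since its step to compound 3 stays within the scatter. Nothing available explains the difference between trifluoromethyl and isopropyl at this position.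

The compounds shown leave open whether a group of another kind here, such as an amine, a carboxylic acid or a longer chain, would move the number well outside the narrow span of these four. They also leave open whether the same picture would hold with something other than the cyclopentyl group on the neighbouring ring atom.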